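This account rests on a few compounds, and the source may have more. Where it says the series, first, only, none or still open, it means among the compounds named here.

Three compounds that share one core have been examined in a functional assay on the whole organism for inhibition, with Brassica napus as the target, with a stated time of 72 h, tested at 10 mg/L; a higher number here means more inhibition of growth at the concentration tested, a lower number less inhibition of growth. Compound 1 `COc1cc(C)nc2n/c(=N/C(=O)c3c(-c4ccc(Cl)cc4Cl)noc3C)sn12` gives 26.4% in this assay, the lowest of the three numbers. Compound 3 `CSc1cc(C)nc2n/c(=N/C(=O)c3c(-c4ccc(Cl)cc4Cl)noc3C)sn12` gives 32.8% in this assay, and the change a number 6.4 percentage points higher from compound 1 to compound 3 (within the scatter) stays within the scatter, so the two cannot be told apart. Among the compounds with values here, compound 2 `CSc1cc(C)nc(NC(=S)NC(=O)c2c(-c3ccc(Cl)cc3Cl)noc2C)n1` gives 42.4% in this assay, which lies beyond the scatter from compound 1; no single-site step links compound 2 with compound 1, so only the two values themselves can be set side by side.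

Compound 4 `COc1cc(Cl)nc2n/c(=N/C(=O)c3c(-c4ccc(Cl)cc4Cl)noc3C)sn12` has not been measured. It differs from compound 1 by chloro in place of methyl on an aromatic carbon. Within the data shown here, no measured step touches this position in this way; the only single step on record, from compound 1 to compound 3, concerns a different group and was within the scatter. No step beyond the scatter is therefore expected in this assay, in either direction. Compound 4 is estimated at 28% in this assay, between 12% and 48%, an expected step of a number 1.6 percentage points higher from compound 1 to compound 4 (within the scatter).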

Compound 4, percent growth inhibition at one concentration: 28.6%
Compound 4: middle estimate off by 0.6 percentage points, on the low side; measured number inside the range.
By their numbers in this assay, from the lowest: compounds 1, 4, 3 and 2 (each within the scatter of the next, the first and the last beyond it).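

Placing chloro where compound 1 carries methyl, on this aromatic carbon of the shared core, gives a number 2.2 percentage points higher from compound 1 to compound 4 (within the scatter) in this assay. This is the first look at this position among the compounds shown, and the exchange leaves no readable mark: compound 4 and compound 1 cannot be told apart at this single test concentration. Nothing measured here bears on the reason for this result.

As far as these compounds go, with only methyl and chloro seen at this position, it remains open whether a larger or very different group there, such as an amine, a carboxylic acid or a longer chain, would move the number beyond the scatter. From the compounds shown here alone, it is also open whether chloro would behave the same way alongside methylsulfanyl, the group carried by compound 3, in place of methoxy.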